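A few compounds are considered here, and "the series" means these few. Any claim that something is new, unique, unknown or untested is made for them only; others in the source may bear on it.

Of the compounds shown here, three have been measured in a functional assay on UACC-257 cells (Homo sapiens) for inhibition, read by sulforhodamine B assay, with a stated time of 48 h; a higher number here means a weaker inhibitor of growth, a lower number a stronger inhibitor of growth. Compound 1 `Nc1cc(N)c2nc(-c3ccccc3)c(Sc3ccc(F)cc3)nc2c1` gives 31600 nM in this assay. Compound 2 `CCOC(=O)[C@H](CCC(=O)O)NC(=O)c1ccc(CNc2nc3cc(N)cc(N)c3nc2-c2ccccc2)cc1` gives 37200 nM, and compound 3 `COc1ccc(CNc2nc3cc(N)cc(N)c3nc2-c2ccccc2)cc1` gives 30200 nM. All three numbers lie within the usual scatter of one another, so compound 1 stands among them with no real separation from either neighbour.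

Compound 4 `COc1ccc(Sc2nc3cc(N)cc(N)c3nc2-c2ccccc2)cc1` has not been measured yet. It differs from compound 1 in one place: methoxy in place of fluoro on an aromatic carbon. Going by the values given here, no measured pair tests this methoxy-for-fluoro exchange directly. Because compound 2 at 37200 nM and compound 3 at 30200 nM stay within the scatter of compound 1 despite larger structural changes, the expected step is a 1.0-fold higher number from compound 1 to compound 4 (0.01 log units; within the scatter), none beyond the scatter. Compound 4 is therefore estimated at 32000 nM, in a range from 15000 nM to 68000 nM.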

Compound 4, concentration for total growth inhibition: < 100000 nM
Compound 4: only a limit was reported; the forecaster's own chance of this, stated with the estimate: 10%; the middle value does not contradict the limit.
By their numbers in this assay, from the lowest: compounds 3, 1 and 2 (each within the scatter of the next).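

In this assay compound 4 gives < 100000 nM, which is a limit and not a number, so the step from compound 1 to compound 4 cannot be read. The compounds shown leave open whether methoxy in place of fluoro changes growth inhibition at all.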